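The source may hold more compounds than are shown below. What is called first, only, known or untested is meant among the compounds shown, and "the series" means these compounds.

In a toxicity assay on the whole organism (strain Icem-CET (SPF Caw)) for cytotoxicity, with Mus musculus as the target (on this read-out lower numbers stand for an effect already at smaller amounts and higher numbers for an effect only at larger amounts of compound), compound 2 `C/C(C(=O)NC1CC1)=C(/C)c1ccccc1` gives 150 mg/kg. Compound 3 `COc1ccc(/C(C)=C(\C)C(=O)NC2CC2)cc1` gives 250 mg/kg in this assay. Compound 1 `C=CCNC(=O)/C(C)=C(/C)c1ccccc1` gives 400 mg/kg.

Compound 2 stands lowest of the three numbers; compound 3 is nearest, with a 1.7-fold higher number from compound 2 to compound 3 (0.22 log units; within the scatter), and compound 1 is furthest, beyond the scatter. Compound 4 `C=CCNC(=O)/C(C)=C(\C)c1ccccc1` differs from compound 2 by allyl in place of cyclopropyl on an amide-type nitrogen. Going by the values given here, the single measured step, from compound 2 to compound 3, lies on the aromatic ring, not on the amide nitrogen, and is within the scatter, so it bears little on this change. Compound 1 also carries an allyl on its amide nitrogen and shows a higher number than compound 2. A moderate rise in this assay is therefore expected, a 2.0-fold higher number from compound 2 to compound 4 (0.30 log units; within the scatter). The estimate for compound 4 is 300 mg/kg, in a range from 150 mg/kg to 600 mg/kg.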

Compound 4, dose for half-maximal effect: 250 mg/kg
The estimate for compound 4 lay 1.2-fold (0.08 log units) above the measured number; low and high end bracket the measured number.
By their numbers in this assay, from the lowest: compounds 2, 3, 4 and 1 (each within the scatter of the next, the first and the last beyond it).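

With allyl in place of cyclopropyl on the amide-type nitrogen, this assay shows a 1.7-fold higher number from compound 2 to compound 4 (0.22 log units; within the scatter), so this change at this position does not separate the two compounds. Reversing the double bond in the allyl amide gives a 1.6-fold lower number from compound 1 to compound 4 (0.20 log units; within the scatter), and this pair isolates the double bond as the only point of difference: the fact that compounds 1 and 4 differ only in the configuration as drawn. Neither change on its own moves the number beyond the scatter.

On these data alone, it remains open whether a longer chain such as butyl, or a carboxylic acid, on the amide-type nitrogen would do so. As far as these compounds go, the effect of methoxy in the allyl amides also remains open.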